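Replacing Furan-3-yl with 5-Chlorofuran-2-yl

This account rests on a few compounds, and the source may have more. Where it says the series, first, only, none or still open, it means among the compounds named here.

In a functional assay on DU-145 cells (Homo sapiens) for cytotoxicity, read by ELISA, with a stated time of 4 days (on this read-out lower numbers stand for stronger inhibition and higher numbers for weaker inhibition), compound 1 (`Cc1ccc(-c2cc(-c3ccoc3)cc(-c3ccc(Cl)s3)n2)cc1`) gives 25300 nM, level with compound 2 (`Clc1cccc(-c2cc(-c3ccoc3)cc(-c3ccc(Cl)s3)n2)c1`) at 23000 nM. Compound 3 (`Cc1ccc(-c2cc(-c3ccc(Cl)o3)cc(-c3ccc(Cl)s3)n2)cc1`) keeps the core of compound 1 but carries 5-chlorofuran-2-yl in place of furan-3-yl on an aromatic carbon. Going by the values given here, the only measured step, a 1.1-fold lower number from compound 1 to compound 2 (0.04 log units; within the scatter), exchanges 4-methylphenyl for 3-chlorophenyl and leaves the furan untouched, so it offers only weak guidance. No shift beyond the scatter is therefore expected in this assay, and the estimated change is a 1.4-fold lower number from compound 1 to compound 3 (0.15 log units; within the scatter). For compound 3 the expected value is 18000 nM, within an estimated range of 6000 nM to 50000 nM.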

Compound 3, half-maximal inhibitory concentration: > 50000 nM
Compound 3: a limit, no number (the forecaster's own chance of this, stated with the estimate: 15%); at least 2.7-fold (0.44 log units) between middle value and limit.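

Swapping the group opposite the ring nitrogen gives an at least 1.9-fold higher number from compound 1 to compound 3 (0.29 log units; that floor lies within the scatter) in this assay, whereas the earlier pair changed only the aryl group at another place. The floor of this step lies within the scatter, so the data show no firm weakening, and they set no upper bound on the change either. Compound 3 gives only a limit of the assay, not a number: the limit of > 50000 nM in this assay, at which 1 of the 3 values shown sits.

The step adds a chlorine and moves the furan attachment together, so neither change can be judged alone. Going by these compounds, how a primary amine or a carboxylic acid at this place would read remains open.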